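Moving the Two Methoxy Groups on the Aryl Ketone

A few compounds are considered here, and "the series" means these few. Any claim that something is new, unique, unknown or untested is made for them only; others in the source may bear on it.

Three compounds have been measured in a functional assay on MCF7 cells (Homo sapiens) for inhibition, read by sulforhodamine B assay, with a stated time of 72 h; a lower number here means a stronger inhibitor, a higher number a weaker inhibitor:
Compound 1, `O=C(/C=C/c1cn(-c2ccccc2)nc1-c1ccncc1)c1ccsc1`, gives 1500 nM.
Compound 2, `O=C(/C=C/c1cn(-c2ccccc2)nc1-c1ccncc1)c1cc[nH]c1`, gives 13600 nM.
Compound 3, `COc1ccc(C(=O)/C=C/c2cn(-c3ccccc3)nc2-c2ccncc2)cc1OC`, gives 4300 nM.

Compound 3 stands second highest of the three numbers. Its nearest neighbour is reached by a 2.9-fold higher number from compound 1 to compound 3 (0.46 log units; beyond the scatter), its furthest by a 3.2-fold lower number from compound 2 to compound 3 (0.50 log units; beyond the scatter).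

Compound 4, `COc1ccc(OC)c(C(=O)/C=C/c2cn(-c3ccccc3)nc2-c2ccncc2)c1`, differs from compound 3 by 2,5-dimethoxyphenyl in place of 3,4-dimethoxyphenyl on a carbonyl carbon. Among the measured compounds shown here, none of the measured steps bears directly on this change: each of a 9.1-fold higher number from compound 1 to compound 2 (0.96 log units; beyond the scatter), a 2.9-fold higher number from compound 1 to compound 3 (0.46 log units; beyond the scatter) and a 3.2-fold lower number from compound 2 to compound 3 (0.50 log units; beyond the scatter) exchanges the group on the carbonyl carbon for a different one, whereas compound 3 and compound 4 have the same atoms, joined differently. Those steps show that the group on the carbonyl carbon can move the number in this assay by modest amounts, but they give no direction for shifting the two methoxy groups within the same ring. The expected step is therefore a 1.0-fold higher number from compound 3 to compound 4 (0.02 log units; within the scatter), within the scatter, with a wide range to allow for either direction. The estimate for compound 4 is 4500 nM, with a range from 1500 nM to 14000 nM.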

Compound 4, half-maximal inhibitory concentration: 1400 nM
Compound 4: middle estimate off by 3.2-fold (0.51 log units), on the high side, outside the stated range (below it).
By their numbers in this assay, from the lowest: compounds 4 and 1 (each within the scatter of the next); then compound 3; then compound 2.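

In this assay the arrangement of the two methoxy groups counts on its own: a 3.1-fold lower number from compound 3 to compound 4 (0.49 log units; beyond the scatter) is a step beyond the scatter, although the group on the carbonyl carbon keeps the same atoms, so this place responds to more than the exchange of one group for another. The result also changes how a dimethoxyphenyl group compares with the other groups at this place, since a 1.1-fold lower number from compound 1 to compound 4 (0.03 log units; within the scatter) leaves the 2,5-dimethoxyphenyl group level with thiophen-3-yl, while a 9.7-fold lower number from compound 2 to compound 4 (0.99 log units; beyond the scatter) sets it well apart from 1H-pyrrol-3-yl, a wider gap than compound 3 shows to compound 2. No evidence is available to explain why moving the methoxy groups shifts the number.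

The compounds shown leave open which of the two methoxy groups carries the step, and whether other dimethoxyphenyl arrangements would side with compound 3 or with compound 4. They also leave open what a phenyl ring with a single methoxy group would give, or one with a hydroxyl group or an amine in place of methoxy.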